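A few compounds are considered here, and "the series" means these few. Any claim that something is new, unique, unknown or untested is made for them only; others in the source may bear on it.

Measured compounds in a functional assay for inhibition, with Homo sapiens as the target; on this read-out lower numbers stand for stronger inhibition and higher numbers for weaker inhibition:
Compound 1 `CNc1nncc2cncn12`; its result is an assay limit, > 48000 nM.
Compound 2 `CNc1nncc2c(C)ncn12`; its result is likewise a limit, > 48000 nM.
Compound 3 `Cc1ncn2c(NCc3ccco3)nncc12`; its result is likewise a limit, > 48000 nM.

Compound 2 stands only at a limit in this assay, and the other two values shown do the same (the limit of > 48000 nM in this assay, at which 3 of the 3 values shown sit). Compound 4 `Cc1ncn2c(N(C)C)nncc12` differs from compound 2 by methyl in place of hydrogen on a nitrogen on an aromatic ring. Within the data shown here, the measured steps that bear on this change are a step that the two limits leave unreadable from compound 1 to compound 2 and a step that the two limits leave unreadable from compound 2 to compound 3; both are left unreadable by the limits at either end, so no measured step supplies a direction or a size. With compound 2 at its limit, compound 4 is expected to stay at or near that limit, and the step that the limit leaves unreadable from compound 2 to compound 4 is estimated as nothing the assay can resolve. Compound 4 is estimated at 70000 nM, within 20000 nM to 300000 nM.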

Compound 4, half-maximal inhibitory concentration: > 48000 nM
Compound 4 was reported as a limit; the forecaster's own chance of this, stated with the estimate: 85%; the middle value is on the limit's open side.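

In this assay compound 4 gives > 48000 nM, an assay limit, and compound 2 is also a limit, so no step can be read between them. The compounds shown leave open whether any of these changes affects inhibition at all, because every value sits at the same limit: the limit of > 48000 nM in this assay, at which 4 of the 4 values shown sit.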